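From 3-bromophenyl to 4-bromophenyl on a sulfonamide

The compounds below may be only part of what the source reports. "The series", "measured", "known", "first", "only" and "open" are said of these compounds alone.

Measured in a functional assay on M21 cells (Homo sapiens) for antiproliferative activity, read by sulforhodamine B assay, with a stated time of 48 h; a higher number here means a weaker inhibitor, a lower number a stronger inhibitor:
Compound 1 `Cc1cccc(NS(=O)(=O)c2ccc(N3CCNC3=O)cc2)c1`: 69 nM
Compound 2 `Cc1ccc(NS(=O)(=O)c2ccc(N3CCNC3=O)cc2)cc1C`: 94 nM
Compound 3 `O=C1NCCN1c1ccc(S(=O)(=O)Nc2cccc(Br)c2)cc1`: 59 nM

The three values cannot be told apart. Compound 3 stands level with the other two, with a 1.2-fold lower number from compound 1 to compound 3 (0.07 log units; within the scatter) and a 1.6-fold lower number from compound 2 to compound 3 (0.20 log units; within the scatter). Compound 4 `O=C1NCCN1c1ccc(S(=O)(=O)Nc2ccc(Br)cc2)cc1` has the same atoms as compound 3, joined differently, with 4-bromophenyl in place of 3-bromophenyl on a sulfonamide nitrogen. For the measured compounds named here, no measured step moves a bromo group, so the evidence is indirect. Adding a methyl to the aromatic ring gave a 1.4-fold higher number from compound 1 to compound 2 (0.13 log units; within the scatter), and exchanging methyl for bromo gave a 1.2-fold lower number from compound 1 to compound 3 (0.07 log units; within the scatter). Since these small steps stay within the scatter, no larger change is expected in this assay. The estimated step is a 1.3-fold higher number from compound 3 to compound 4 (0.10 log units; within the scatter). Compound 4 is expected at 75 nM, with an estimated range of 30 nM to 190 nM.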

Compound 4, half-maximal inhibitory concentration: 130 nM
The estimate for compound 4 lay 1.7-fold (0.24 log units) below the measured number; measured number inside the range.
By their numbers in this assay, from the lowest: compounds 3, 1, 2 and 4 (each within the scatter of the next, the first and the last beyond it).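

Moving the bromo group gives the first step in this set that goes beyond the scatter in this assay (a 2.2-fold higher number from compound 3 to compound 4 (0.34 log units; beyond the scatter)), so 3-bromophenyl and 4-bromophenyl on a sulfonamide nitrogen can be told apart here. The other two comparisons stay within the scatter (a 1.4-fold higher number from compound 2 to compound 4 (0.14 log units; within the scatter); a 1.9-fold higher number from compound 1 to compound 4 (0.28 log units; within the scatter)), so compound 4 is separated only from compound 3. Nothing available explains the difference between the two bromophenyl groups.

Still open, going by these compounds, is whether the effect belongs to bromo alone. 4-Methylphenyl or 4-aminophenyl on the same nitrogen could show whether other groups follow the same pattern.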